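The source may report more compounds than this note shows. Statements on the series, on what has been measured and on what is new or still open speak of the compounds shown alone.

The measured compounds in a functional assay on K562 cells (Homo sapiens) for antiproliferative activity, read by MTT assay, with a stated time of 48 h; a higher number here means a weaker inhibitor, a lower number a stronger inhibitor:
Compound 1, `Cc1ccc(-c2ccc3c(c2)C(=O)C(=O)N3)cc1`, gives only a limit of the assay, > 10000 nM.
Compound 2, `COc1ccc(-c2ccc3c(c2)C(=O)C(=O)N3c2ccc(OC)cc2)cc1`, likewise gives only a limit, > 10000 nM.
Compound 3, `COc1ccc(-c2ccc3c(c2)C(=O)C(=O)N3Cc2cccc(Cl)c2)cc1`, gives 200 nM.

Within the data shown here, compound 3 therefore stands as the only compound with an actual number in this assay; the other two sit at a limit, as the limit of > 10000 nM in this assay, at which 2 of the 3 values shown sit, records. Among the measured compounds shown here, the one step that can be sized is an at least 50-fold lower number from compound 2 to compound 3 (1.69 log units; beyond the scatter), a large change, and it shows that what sits on the ring nitrogen matters greatly, with the 3-chlorobenzyl group giving a measurable number where the 4-methoxyphenyl group gave none.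

Compound 4, `COc1ccc(-c2ccc3c(c2)C(=O)C(=O)N3Cc2ccc3ccccc3c2)cc1`, differs from compound 3 by naphthalen-2-yl in place of 3-chlorophenyl on a saturated chain carbon bound to an amide-type nitrogen in a ring. The measured step does not bear directly on this change: it exchanged the whole group on the nitrogen, whereas here the saturated chain carbon on the nitrogen is kept and only the aromatic part attached to it is swapped. For the measured compounds named here, no measured pair varies that aromatic part, so the expectation rests on compound 3 alone, and the step is expected to stay within the scatter, a 1.3-fold higher number from compound 3 to compound 4 (0.10 log units; within the scatter). For compound 4 the estimate is 250 nM, with a range from 80 nM to 800 nM.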

Compound 4, half-maximal inhibitory concentration: 400 nM
Beside the measured number, compound 4's estimate is 1.6-fold (0.20 log units) below it; the range from low to high includes it.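

In this assay, the exchange reads as a 2.0-fold higher number from compound 3 to compound 4 (0.30 log units; within the scatter), so naphthalen-2-yl and 3-chlorophenyl on a saturated chain carbon bound to an amide-type nitrogen in a ring cannot be told apart. The earlier step replaced the whole group on the nitrogen, whereas this one keeps the saturated chain carbon and varies only the aromatic part, showing that a number in the assay survives the loss of the chlorine and the move from one six-membered aromatic ring to two, with 10 heavy atoms entering where 7 leave. No measurement shown offers a reason for this result.

The compounds shown leave open how a longer chain in place of the single saturated chain carbon would read, and whether that carbon is needed at all. They also leave open whether an aromatic part carrying an amine or a carboxylic acid, or a pyridine ring in place of the carbon-only rings, would still give a number in this assay.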